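Sulfonamide nitrogen substituent swap in an antiproliferative series

The compounds below may be only part of what the source reports. "The series", "measured", "known", "first", "only" and "open" are said of these compounds alone.

Three compounds of the series have so far been run in a functional assay on A549 cells (Homo sapiens) for antiproliferative activity, read by CCK-8 assay, with a stated time of 72 h; a higher number here means a weaker inhibitor of growth, a lower number a stronger inhibitor of growth. Compound 1 `CC[C@@H]1C(=O)N(C)c2cnc(-n3ccc4cc(F)ccc43)nc2N1C1CCCC1` gives "not active" (no number reported) and so returns no number. Compound 3 `CCC1C(=O)N(C)c2cnc(-n3ccc4cc(F)ccc43)nc2N1c1ccn(C)n1` likewise gives "not active" (no number reported) in this assay. Within the data shown here, compound 2 `CC[C@@H]1C(=O)N(C)c2cnc(Nc3ccc(S(=O)(=O)NC4CCCC4)cc3)nc2N1C1CCCC1` is the only member with a numeric result: in this assay compound 2 gives 1150 nM. Among the measured compounds shown here, it therefore stands alone, and no comparison among measured compounds can be drawn from the numbers in hand.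

Compound 4 `CC[C@@H]1C(=O)N(C)c2cnc(Nc3ccc(S(=O)(=O)Nc4ccccc4)cc3)nc2N1C1CCCC1` differs from compound 2 in a single place: phenyl in place of cyclopentyl on a sulfonamide nitrogen. For the measured compounds named here, no pair of measured compounds isolates this change, and the two other entries carry no number, so the size of the step has to be judged without a precedent. The expectation is that the step stays small, in either direction, and most likely within the usual scatter; the expected step is a 1.2-fold lower number from compound 2 to compound 4 (0.06 log units; within the scatter). Compound 4 is accordingly estimated at 1000 nM in this assay, with a range from 350 nM to 3000 nM that allows for a moderate move either way, a wider band than usual given the absence of any guiding step.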

Compound 4, concentration for 50% growth inhibition: 4150 nM
Compound 4: middle estimate off by 4.2-fold (0.62 log units), on the low side; the whole stated range lies below it.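

The sulfonamide nitrogen now has its first readable step: in this assay, phenyl in place of cyclopentyl gives a 3.6-fold higher number from compound 2 to compound 4 (0.56 log units; beyond the scatter), so the group on this nitrogen does affect the read-out, and here the aromatic ring gives the higher number of the two. The swap still leaves a numeric result, with compound 4 at 4150 nM, while no steps can be read for compound 1 or compound 3, which differ from the sulfonamides in more than one place and carry no number. No measured information on these compounds bears on the direction or size of this step.

This single pair changes ring size and aromatic character together, so it cannot show which of the two goes with the higher number; cyclohexyl on the same nitrogen would separate them. Also open, as far as these compounds go, is how the read-out responds on this nitrogen to a small alkyl group such as methyl, a longer chain such as n-butyl, a pyridyl ring, or a chain ending in an amine or a carboxylic acid.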